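The source may report more compounds than this note shows. Statements on the series, on what has been measured and on what is new or still open speak of the compounds shown alone.

Measured in an in vitro ADME assay on microsomes from liver (Rattus norvegicus) for metabolic stability, tested at 2 uM; on this read-out lower numbers stand for a shorter-lived compound and higher numbers for a longer-lived compound:
- compound 1 `O=C(O)C#Cc1ccc(NC(=O)CSc2nnnn2-c2ccc(C3CC3)cc2Cl)c(Cl)c1`: 0.333 h
- compound 2 `CC(C)(O)C#Cc1ccc(NC(=O)CSc2nnnn2-c2ccc(C3CC3)cc2Cl)c(Cl)c1`: 1.4 h
- compound 3 `CC(C)(N)C#Cc1ccc(NC(=O)CSc2nnnn2-c2ccc(C3CC3)cc2Cl)c(Cl)c1`: 0.517 h

The data show a 1.6-fold higher number from compound 1 to compound 3 (0.19 log units; within the scatter), but also a 2.7-fold lower number from compound 2 to compound 3 (0.43 log units; beyond the scatter). So compound 3 cannot be told apart from compound 1, while compound 2 stands clear of it. Compound 4 `CC(C)(C#Cc1ccc(NC(=O)CSc2nnnn2-c2ccc(C3CC3)cc2Cl)c(Cl)c1)C(=O)O` follows from compound 3 through carboxy in place of amino on a saturated chain carbon bound to two saturated chain carbons and a triple-bonded carbon: carboxy in place of amino. Among the measured compounds shown here, no measured step makes this exact swap. The closest evidence is the carboxy-bearing compound 1, whose link to the amino compound is a 1.6-fold higher number from compound 1 to compound 3 (0.19 log units; within the scatter), whereas a 4.2-fold higher number from compound 1 to compound 2 (0.62 log units; beyond the scatter) concerns hydroxy. The expected change is therefore a 1.4-fold higher number from compound 3 to compound 4 (0.13 log units; within the scatter), with no shift beyond the scatter. Compound 4 is estimated at 0.7 h, with an expected range of 0.3 h to 1.6 h.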

Compound 4, half-life: 1.5 h
The estimate for compound 4 lay 2.1-fold (0.33 log units) below the measured number, within the range that was stated.
By their numbers in this assay, from the lowest: compounds 1 and 3 (each within the scatter of the next); then compounds 2 and 4 (each within the scatter of the next).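

In this assay, the saturated chain carbon bound to two saturated chain carbons and a triple-bonded carbon tolerates carboxy as well as hydroxy, and amino alone stands apart there (a 2.9-fold higher number from compound 3 to compound 4 (0.46 log units; beyond the scatter); a 1.1-fold higher number from compound 2 to compound 4 (0.03 log units; within the scatter)). A carboxy group does not go with a short half-life in every compound here, as moving it from the triple-bonded carbon onto this carbon shows (a 4.5-fold higher number from compound 1 to compound 4 (0.65 log units; beyond the scatter)). Nothing measured here explains these steps.

The compounds shown leave open whether a methyl ester or a primary amide on this carbon would match compound 4 or compound 3, and what a longer chain carrying the carboxy would give.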